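Pyridin-4-yl for pyridin-3-yl: cytotoxicity notes on a thiophene series

This account rests on a few compounds, and the source may have more. Where it says the series, first, only, none or still open, it means among the compounds named here.

Measured so far:
compound 1, `Clc1ccc2c(NCCNCc3ccc(-c4cccnc4)s3)ccnc2c1`: 16400 nM
compound 2, `Clc1ccc2c(NCCCNCc3ccc(-c4cccnc4)s3)ccnc2c1`: 21600 nM
compound 3, `Clc1ccc2c(NCCNCc3ccc(-c4ccncc4)s3)ccnc2c1`: 6330 nM

All values come from an ADME assay on PBMC cells (Homo sapiens) for cytotoxicity, read by MTT assay, with a stated time of 48 h; a higher number here means a weaker inhibitor, a lower number a stronger inhibitor. Compound 1 and compound 2 differ in their cores; the difference between the two cores is not broken down here. Compound 3 carries one change relative to compound 1, (pyridin-4-yl in place of pyridin-3-yl on an aromatic carbon), and that change gave a 2.6-fold lower number from compound 1 to compound 3 (0.41 log units; beyond the scatter). Compound 2 has the highest number of the three, though its value and that of compound 1 lie within the scatter of each other.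

Compound 4, `Clc1ccc2c(NCCCNCc3ccc(-c4ccncc4)s3)ccnc2c1`, is not yet measured in this assay. It carries the same change relative to compound 2, (pyridin-4-yl in place of pyridin-3-yl on an aromatic carbon). For the measured compounds named here, for compound 4 a step of a 2.5-fold lower number from compound 2 to compound 4 (0.41 log units; beyond the scatter) is expected, and this rests on compound 3 alone, because a 2.6-fold lower number from compound 1 to compound 3 (0.41 log units; beyond the scatter) is the only measured instance of the change. Compound 4 is thus estimated at 8500 nM, with a likely range from 4000 nM to 18000 nM.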

Compound 4, half-maximal inhibitory concentration: 3320 nM
Beside the measured number, compound 4's estimate is 2.6-fold (0.41 log units) above it; measured number outside the range, below it.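

In this assay, pyridin-4-yl in place of pyridin-3-yl on the second core gives a 6.5-fold lower number from compound 2 to compound 4 (0.81 log units; beyond the scatter), in the same direction as the step on the first core. The two steps do not differ beyond what repeated measurement allows: the same change on two cores in this assay, a 2.6-fold lower number (0.41 log units; beyond the scatter) from compound 1 to compound 3 and a 6.5-fold lower number (0.81 log units; beyond the scatter) from compound 2 to compound 4, 2.5-fold (0.40 log units) apart, within the scatter of two such steps

Across these two cores, the change can therefore be carried over with a lower number each time, and the larger second step should not be read as a stronger effect of that core; two pairs do not show that the same would hold on any other core, and they give no reason for the step.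

Still open, going by these compounds, is whether a phenyl or pyrimidin-5-yl ring in the same place would follow the pyridin-4-yl compounds. Also open, on these data alone, is whether the step would persist with a longer chain between the two amine nitrogens.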